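Trifluoromethyl for Methyl: an Expected Step in Potency

A few compounds are considered here, and "the series" means these few. Any claim that something is new, unique, unknown or untested is made for them only; others in the source may bear on it.

Measured compounds:
compound 1 `CC(C)(C)c1ccc(/C(=C/C(=O)Nc2ccc3c(c2)OCCO3)c2ccncc2)cc1` — 44 nM
compound 2 `Cc1ccc(/C=C/C(=O)Nc2ccc3c(c2)OCCO3)cc1` — 210 nM

Of the compounds shown here, two sharing the same amide-linked core have been measured in a functional assay on CHO cells for inhibition of transient receptor potential cation channel subfamily V member 1 (Homo sapiens); on this read-out higher numbers stand for weaker inhibition and lower numbers for stronger inhibition. Compound 1 gives 44 nM, while compound 2 gives 210 nM. Within the data shown here, compound 2 thus stands at the higher of the two numbers, and the gap to compound 1 lies beyond the scatter; the two structures differ in more than one place, however, so no single step connects them, and their values only show that compound 1 is the stronger inhibitor of the pair.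

Compound 3 `O=C(/C=C/c1ccc(C(F)(F)F)cc1)Nc1ccc2c(c1)OCCO2` has not yet been measured in this assay. It differs from compound 2 in one place: trifluoromethyl in place of methyl on an aromatic carbon. Among the measured compounds shown here, no measured pair isolates this change, so the direction of the step is uncertain. The step from compound 2 to compound 3 is expected to be a 1.8-fold lower number from compound 2 to compound 3 (0.24 log units; within the scatter), a small lowering of the number that may not exceed the scatter. For compound 3 the estimated value in this assay is 120 nM, within a range from 35 nM to 420 nM.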

Compound 3, half-maximal inhibitory concentration: 46 nM
The estimate for compound 3 lay 2.6-fold (0.42 log units) above the measured number; the range from low to high includes it.
By their numbers in this assay, from the lowest: compounds 1 and 3 (each within the scatter of the next); then compound 2.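

In this assay, among these compounds, the exchange of methyl for trifluoromethyl on an aromatic carbon, para to a large group, gives a 4.6-fold lower number from compound 2 to compound 3 (0.66 log units; beyond the scatter), and this is the first comparison here that isolates a single change. Since the step lies beyond the scatter, this position on the ring is shown to respond to the identity of its group, even though the change adds no ring, hydrogen-bond donor, hydrogen-bond acceptor or net charge. No measurement bears on the origin of this step, so the result gives its direction and size but no explanation.

As far as these compounds go, with only compound 2 and compound 3 forming a one-place pair, it remains open how a chlorine atom, a methoxy group or a nitrile at the same place would compare with methyl and trifluoromethyl on this scale. From the compounds shown here alone, it also remains open whether the same exchange of methyl for trifluoromethyl would give a step of similar size on the core of compound 1, or whether the step seen here is tied to the simpler core of compound 2.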